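This account rests on a few compounds, and the source may have more. Where it says the series, first, only, none or still open, it means among the compounds named here.

Measured so far in a functional assay on SN12C cells (Homo sapiens) for cytotoxicity, read by sulforhodamine B assay, with a stated time of 48 h; a lower number here means that less compound is tolerated, a higher number that more compound is tolerated:
- compound 1 `ClCc1ccc(Cn2cnc3c(Cl)ncnc32)cc1`: 5370 nM
- compound 2 `ClCc1cccc(Cn2cnc3c(Cl)nc(Cl)nc32)c1`: 11800 nM
- compound 3 `ClCc1ccccc1Cn1cnc2ncnc(Cl)c21`: 42700 nM

Compound 1 holds the lowest number of the three. The nearest is compound 2, whose value sits higher by a gap beyond the scatter; compound 3 lies further off, higher still, also beyond the scatter. Compounds 2 and 3 differ from compound 1 in more than one place, so no single change among the measured compounds is isolated.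

Compound 4 `ClCc1ccc(Cn2cnc3c(Cl)nc(Cl)nc32)cc1` is not yet measured. It differs from compound 1 by chloro in place of hydrogen on an aromatic carbon. Among the compounds with values here, no measured pair shows the effect of this change alone, so the size of the step in this assay is open; a shift of modest size in either direction, or none beyond the scatter, is plausible. The estimate for compound 4 is 7000 nM (range 2500 nM to 20000 nM), an expected step of a 1.3-fold higher number from compound 1 to compound 4 (0.12 log units; within the scatter).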

Compound 4, concentration lethal to 50% of the cells: 51300 nM
Compound 4: the middle estimate sits 7.3-fold (0.87 log units) below what was measured; measured number outside the range, above it.
By their numbers in this assay, from the lowest: compound 1; then compound 2; then compounds 3 and 4 (each within the scatter of the next).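

Chloro in place of hydrogen on an aromatic carbon, between two ring nitrogen atoms, gives in this assay a 9.6-fold higher number from compound 1 to compound 4 (0.98 log units; beyond the scatter). Within the data shown here, this is the first single change isolated, and it shows that this position is not neutral: one added chlorine moves the number beyond the scatter, towards more compound tolerated. Nothing at hand accounts for the size of this step.

Going by these compounds, whether an amine or a methoxy group on the same carbon moves the number in the same direction remains open. Also open, on these data alone, is whether the same chloro change on compound 3 gives a step of similar size.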